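Closing the Amino Acid Chain into an Azetidine Ring

This account rests on a few compounds, and the source may have more. Where it says the series, first, only, none or still open, it means among the compounds named here.

Of the compounds shown here, two have been measured in an assay on Sf9 cells for inhibition of Amine oxidase [flavin-containing] B (Homo sapiens), with stated times of 15 min and 60 min (a lower number here means a stronger inhibitor, a higher number a weaker inhibitor), so far. Compound 1 `NC(=O)[C@@H]1CCN1Cc1ccc(OCc2cccc(F)c2)cc1Cl` carries a carbamoylazetidinyl group and gives 35 nM in this assay. Compound 2 `C[C@H](NCc1ccc(OCc2cccc(F)c2)cc1F)C(N)=O` instead bears an open (1-carbamoylethyl)amino chain, and in this assay compound 2 gives 61 nM, a value that sits within the usual scatter of the result for compound 1; the two numbers cannot be told apart with confidence. Compound 3 `NC(=O)[C@@H]1CCN1Cc1ccc(OCc2cccc(F)c2)cc1F` has not been measured. It differs from compound 2 by 2-carbamoylazetidin-1-yl in place of (1-carbamoylethyl)amino on a saturated chain carbon bound to an aromatic carbon. Since compound 1 and compound 2 give values that lie within the scatter of each other, and compound 1 already carries the cyclic group that enters here, compound 3 is expected to show a step of a 1.4-fold lower number from compound 2 to compound 3 (0.13 log units; within the scatter), that is, no change beyond the scatter. The estimate for compound 3 in this assay is 45 nM, with a range from 15 nM to 130 nM.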

Compound 3, half-maximal inhibitory concentration: 26 nM
The estimate for compound 3 lay 1.7-fold (0.24 log units) above the measured number; the measured number falls inside the stated range.
By their numbers in this assay, from the lowest: compounds 3, 1 and 2 (each within the scatter of the next, the first and the last beyond it).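

In this assay, with the fluoro compounds now compared directly, 2-carbamoylazetidin-1-yl in place of (1-carbamoylethyl)amino on a saturated chain carbon bound to an aromatic carbon gives a 2.3-fold lower number from compound 2 to compound 3 (0.37 log units; beyond the scatter) and so shows a modest gain from the ring that compound 1 and compound 2, which differ in two places, could not show. Fluoro in place of chloro on an aromatic carbon, with the 2-carbamoylazetidin-1-yl group kept, gives a 1.3-fold lower number from compound 1 to compound 3 (0.13 log units; within the scatter) and so this halogen change cannot be told from the scatter. No measurement here accounts for the step to the ring.

The compounds shown leave open whether a carboxylic acid in place of the carbamoyl group would keep these numbers. They also leave open whether an open chain with a methyl group on its amine nitrogen would match the ring.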